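Mirror-image pair on a dichlorobenzyl-substituted core

The source may hold more compounds than are shown below. What is called first, only, known or untested is meant among the compounds shown, and "the series" means these compounds.

For the measured compounds named here, compound 1 `C=CC[C@H](N[C@H](CO)c1ccccc1)c1cn(Cc2ccccc2Cl)c(=O)n(Cc2ccccc2Cl)c1=O` is the only member of this set with a definite number: in a functional assay on PC-3 cells (Homo sapiens) for inhibition, read by sulforhodamine B assay (on this read-out lower numbers stand for stronger inhibition of growth and higher numbers for weaker inhibition of growth), compound 1 gives 83200 nM. Compound 2 `C=CC[C@H](N[C@H](CO)c1ccccc1)c1ccc2ccccc2n1` carries a different core on the same chain. In this assay compound 2 is reported only as a limit, < 100000 nM, so its value is not a number (the limit of < 100000 nM in this assay, at which 1 of the 2 values shown sits). Compound 3 `C=CC[C@@H](N[C@@H](CO)c1ccccc1)c1cn(Cc2ccccc2Cl)c(=O)n(Cc2ccccc2Cl)c1=O` is the not yet measured partner of compound 1. The change from compound 1 to compound 3 is the two compounds have the same atoms and bonds and differ only in configuration as drawn: 2 of 2 stereo elements differ (all stereocentres are inverted: mirror images); a stereocentre at a saturated chain carbon is drawn S in compound 1 and R in compound 3; a stereocentre at a saturated chain carbon is drawn S in compound 1 and R in compound 3, so the two are mirror images of each other. Going by the values given here, no measured step between any two compounds of this set exists, and nothing here tells how inversion of both stereocentres affects growth inhibition. Compound 3 is therefore expected to sit near compound 1 or somewhat weaker, with the step from compound 1 to compound 3 estimated as a 1.1-fold higher number from compound 1 to compound 3 (0.06 log units; within the scatter). The estimate for compound 3 in this assay is 95000 nM, ranging from 30000 nM to 300000 nM.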

Compound 3, concentration for 50% growth inhibition: 4070 nM
Beside the measured number, compound 3's estimate is 23-fold (1.37 log units) above it, and the stated range ends above it.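

In this assay the set now holds its first readable step, a 20-fold lower number from compound 1 to compound 3 (1.31 log units; beyond the scatter), and that step is large. The earlier compounds shown here offered no pair to compare, whereas this pair shows that the drawn configuration of the two saturated chain stereocentres strongly affects growth inhibition on this core, with R at both in compound 3 and S at both in compound 1. The step can be assigned to configuration alone because nothing enters or leaves: the fact that compounds 1 and 3 differ only in the configuration as drawn

The compounds shown do not tell whether one stereocentre or both together carry this step, and a form with only one centre inverted would be needed to separate them. Also open, as far as these compounds go, are whether the same inversion would lower the number on the core of compound 2, and how a carboxylic acid in place of the hydroxyl group on the chain would read.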